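The source may hold more compounds than are shown below. What is called first, only, known or untested is meant among the compounds shown, and "the series" means these compounds.

Measured compounds:
Compound 1 `COc1ccc(OC)c(/C=C/C(=O)C(=Cc2cc(OC)c(O)c(OC)c2)C(=O)/C=C/c2cc(OC)ccc2OC)c1`: in a functional assay on HepG2 cells (Homo sapiens) for antiproliferative activity, read by sulforhodamine B assay, with a stated time of 48 h (on this read-out higher numbers stand for weaker inhibition and lower numbers for stronger inhibition), compound 1 gives 210 nM.
Compound 2 `COc1ccc(OC)c(/C=C/C(=O)C(=Cc2ccc(OC)c(O)c2)C(=O)/C=C/c2cc(OC)ccc2OC)c1`: compound 2 gives 470 nM.
Compound 3 `COc1ccc(/C=C/C(=O)C(=Cc2cc(OC)c(O)c(OC)c2)C(=O)/C=C/c2ccc(OC)cc2OC)c(OC)c1`: compound 3 gives 320 nM.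

Compound 1 and compound 2 share one core and differ in a single ring: 3-hydroxy-4-methoxyphenyl in place of 4-hydroxy-3,5-dimethoxyphenyl on a double-bonded chain carbon bound to a double-bonded chain carbon. That swap made a 2.2-fold higher number from compound 1 to compound 2 (0.35 log units; beyond the scatter), a weakening that lies beyond the ordinary scatter of such measurements.

Compound 3 is built from the same atoms as compound 1, joined differently; the difference between the two cores is not broken down here. Its value sits within the scatter of both compound 1 and compound 2, so no order among the three can be read from it.

Compound 4 `COc1ccc(/C=C/C(=O)C(=Cc2ccc(OC)c(O)c2)C(=O)/C=C/c2ccc(OC)cc2OC)c(OC)c1` is not yet measured. It stands to compound 3 as compound 2 stands to compound 1: 3-hydroxy-4-methoxyphenyl in place of 4-hydroxy-3,5-dimethoxyphenyl on a double-bonded chain carbon bound to a double-bonded chain carbon. The place of the change is the same in both pairs, so this is the same change on a different core.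

Within the data shown here, because the only prior example of this swap gave a 2.2-fold higher number from compound 1 to compound 2 (0.35 log units; beyond the scatter), a step of about a 2.2-fold higher number from compound 3 to compound 4 (0.34 log units; beyond the scatter) is expected here too, with wider uncertainty since the core differs. Compound 4 is therefore estimated at 700 nM, plausibly between 350 nM and 1400 nM.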

Compound 4, half-maximal inhibitory concentration: 390 nM
Compound 4: the middle estimate sits 1.8-fold (0.25 log units) above what was measured; measured number inside the range.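

On the core of compound 3, in this assay, putting 3-hydroxy-4-methoxyphenyl in place of 4-hydroxy-3,5-dimethoxyphenyl gave a 1.2-fold higher number from compound 3 to compound 4 (0.09 log units; within the scatter), a step too small to tell apart from the ordinary spread of repeated measurements. Set beside the earlier case, the two steps cannot be told apart either: the same change on two cores in this assay, a 2.2-fold higher number (0.35 log units; beyond the scatter) from compound 1 to compound 2 and a 1.2-fold higher number (0.09 log units; within the scatter) from compound 3 to compound 4, 1.8-fold (0.26 log units) apart, within the scatter of two such steps

So the results are compatible with the swap acting alike on both cores, but two pairs, one step beyond the scatter and one within it, do not prove that it carries over, nor that the core alters it.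

All the rings shown on a double-bonded chain carbon bound to a double-bonded chain carbon carry a hydroxy group and methoxy groups, so it stays open what an amine or a carboxylic acid there would do. As far as these compounds go, it also stays open whether the swap would read the same way in cells other than HepG2.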